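A Bromine Shift on the Phenyl Ring

The source may hold more compounds than are shown below. What is called first, only, known or untested is meant among the compounds shown, and "the series" means these compounds.

Among the compounds with values here, compound 2 `Fc1ccc(/C=N/Nc2nc(-c3ccc(Br)cc3)cs2)cc1F` is one of two compounds measured in a functional assay on Caco-2 cells (Homo sapiens) for inhibition, read by MTT assay, with a stated time of 48 h; a higher number here means a weaker inhibitor, a lower number a stronger inhibitor. There compound 2 gives 43900 nM, the lower of the two numbers, while compound 1 `COc1cc(/C=N/Nc2nc(-c3ccccc3)cs2)cc(Br)c1OC` gives 64200 nM; the gap between them lies within the scatter, so the two cannot be ranked against each other. Compound 3 `Fc1ccc(/C=N/Nc2nc(-c3cccc(Br)c3)cs2)cc1F` has not yet been measured. It keeps every atom of compound 2 and differs only in how they are joined: 3-bromophenyl in place of 4-bromophenyl on an aromatic carbon. Within the data shown here, no step between two measured compounds is available to guide a forecast, and the pair of numbers in hand says only that two compounds that each bear a bromophenyl land close together. This change is therefore expected to amount to a step of a 1.1-fold higher number from compound 2 to compound 3 (0.06 log units; within the scatter), with no clear direction beyond the scatter. Compound 3 is expected to give about 50000 nM in this assay, with a range from 20000 nM to 130000 nM.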

Compound 3, half-maximal inhibitory concentration: 17500 nM
For compound 3 the middle estimate is 2.9-fold (0.46 log units) above the measured one; the whole stated range lies above it.
By their numbers in this assay, from the lowest: compound 3; then compounds 2 and 1 (each within the scatter of the next).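

Swapping 4-bromophenyl for 3-bromophenyl on an aromatic carbon, with the same atoms joined differently, gives a 2.5-fold lower number from compound 2 to compound 3 (0.40 log units; beyond the scatter) in this assay. Within the data shown here, this is the first comparison here between compounds that differ in one place, and it shows that where the bromine sits on this phenyl ring matters in this assay, by a modest step that lies beyond the scatter. Nothing available explains why the number falls with this change.

From the compounds shown here alone, whether another group, such as a chlorine, a methyl or an amine, would give a similar step in place of the bromine remains open. Going by these compounds, it is also open whether moving the bromine would give a step of similar size if the rest of the shared core carried other groups.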